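Methoxy for Ethoxy: Expected Potency of Compound 4

The compounds below may be only part of what the source reports. "The series", "measured", "known", "first", "only" and "open" are said of these compounds alone.

Compound 1, `COc1ncc(-c2nc(C(F)(F)F)sc2N2CCN(C(=O)Cn3cnc4cccnc43)[C@H](C)C2)cn1`, 177 nM
Compound 2, `CCOc1ncc(-c2nc(C(F)(F)F)sc2N2CCN(C(=O)Cn3cnc4ccccc43)[C@H](C)C2)cn1`, 49 nM
Compound 3, `CCOc1ncc(-c2nc(C(F)(F)F)sc2N2CCN(C(=O)Cn3nc(C)nc3C)[C@H](C)C2)cn1`, 173 nM

Among the compounds with values here, in a functional assay on U2OS cells for antagonist activity at C-X-C chemokine receptor type 3 (Homo sapiens), read by beta-arrestin recruitment (on this read-out higher numbers stand for weaker inhibition and lower numbers for stronger inhibition), compound 3 holds the second highest of three numbers; compound 1 sits within the scatter of it, while compound 2 lies further off, the only single-point step measured being a 3.5-fold higher number from compound 2 to compound 3 (0.55 log units; beyond the scatter). Compound 4, `COc1ncc(-c2nc(C(F)(F)F)sc2N2CCN(C(=O)Cn3nc(C)nc3C)[C@H](C)C2)cn1`, differs from compound 3 by hydrogen in place of methyl on a saturated chain carbon bound to an oxygen on an aromatic ring. Within the data shown here, no measured step bears on this change: compound 1 and compound 2 differ at the alkoxy group but also at the group on the carbonyl-bound carbon, so their values show nothing about the alkoxy change alone. Compound 4 is therefore expected to show no step beyond the scatter, a 1.0-fold lower number from compound 3 to compound 4 (0.01 log units; within the scatter), with an estimate of 170 nM and a range of 80 nM to 400 nM.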

Compound 4, half-maximal inhibitory concentration: 558 nM
Compound 4: the middle estimate sits 3.3-fold (0.52 log units) below what was measured, and the stated range ends below it.
By their numbers in this assay, from the lowest: compound 2; then compounds 3 and 1 (each within the scatter of the next); then compound 4.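

In this assay, the alkoxy group on the pyrimidine proves to matter: with the 3,5-dimethyl-1H-1,2,4-triazol-1-yl group held constant, ethoxy to methoxy gives a 3.2-fold higher number from compound 3 to compound 4 (0.51 log units; beyond the scatter). With methoxy held constant, the group on the saturated chain carbon bound to a carbonyl carbon also counts, with the group of 7 heavy atoms in place of the group of 9 giving a 3.2-fold higher number from compound 1 to compound 4 (0.50 log units; beyond the scatter). Nothing measured explains either step. On these data alone, how a propoxy group or a longer chain would read at this position remains open, as does whether the ethoxy-to-methoxy step holds with other groups on the carbonyl side.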